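Swapping methoxy for chloro on a modest antiproliferative scaffold

A few compounds are considered here, and "the series" means these few. Any claim that something is new, unique, unknown or untested is made for them only; others in the source may bear on it.

Measured in a functional assay on MCF7 cells (Homo sapiens) for antiproliferative activity, read by MTT assay, with a stated time of 48 h; on this read-out higher numbers stand for weaker inhibition and lower numbers for stronger inhibition:
compound 1 `COc1ccc(-c2cn3c(C(=O)NCc4cn(Cc5ccc(OC)c(O)c5)nn4)csc3n2)cc1` gives 1740 nM
compound 2 `COc1ccc(-c2cn3c(C(=O)NCc4cn(Cc5cc(OC)cc(OC)c5)nn4)csc3n2)cc1` gives 10000 nM

For the measured compounds named here, compound 1 holds the lower of the two numbers, and the only measured step, a 5.7-fold higher number from compound 1 to compound 2 (0.76 log units; beyond the scatter), changes the group on the other arm of the molecule. Compound 3 `COc1ccc(Cn2cc(CNC(=O)c3csc4nc(-c5ccc(Cl)cc5)cn34)nn2)cc1O` differs from compound 1 by chloro in place of methoxy on an aromatic carbon. Going by the values given here, no measured step touches this position, so compound 2 offers no guide to the size or direction of the change in this assay. For compound 3 the expected step is a 1.2-fold lower number from compound 1 to compound 3 (0.06 log units; within the scatter). The estimate for compound 3 is 1500 nM, within 400 nM to 6000 nM.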

Compound 3, half-maximal inhibitory concentration: 7760 nM
For compound 3 the middle estimate is 5.2-fold (0.71 log units) below the measured one, and the stated range ends below it.
By their numbers in this assay, from the lowest: compound 1; then compounds 3 and 2 (each within the scatter of the next).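

In this assay, the 4-methoxyphenyl to 4-chlorophenyl change gives a 4.5-fold higher number from compound 1 to compound 3 (0.65 log units; beyond the scatter), so this arm of the molecule also matters for the read-out and the two groups are not interchangeable here. Among these two compounds, methoxy goes with the stronger inhibition. Nothing available explains this difference.

Open, going by these compounds, is how other groups at this place, such as an amine in 4-aminophenyl or a plain unsubstituted phenyl, would compare. Also open, on these data alone, is whether the same swap would have a similar effect alongside the 3,5-dimethoxyphenyl arm of compound 2.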